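Chloro for Fluoro on Two Related Cores

A few compounds are considered here, and "the series" means these few. Any claim that something is new, unique, unknown or untested is made for them only; others in the source may bear on it.

Compound 1 `CNc1ccc(/C=C/c2c(F)cccc2F)cn1` and compound 2 `CNc1ccc(/C=C/c2c(F)cccc2Cl)cn1` share one core; compound 3 `CN(C)c1ncc(/C=C/c2c(F)cccc2Cl)cn1` and compound 4 `CN(C)c1ncc(/C=C/c2c(Cl)cccc2Cl)cn1` share another, and the difference between the two cores is not broken down here. In a functional assay on LS174T cells (Homo sapiens) for antiproliferative activity (on this read-out lower numbers stand for stronger inhibition and higher numbers for weaker inhibition), compound 1 gives 30.1 nM, while compound 2 gives 4 nM. That step is a 7.5-fold lower number from compound 1 to compound 2 (0.88 log units; beyond the scatter), and the change behind it is chloro in place of fluoro on an aromatic carbon. Compound 3 reaches only a limit of this assay, > 200 nM. Compound 4 carries the same kind of change relative to compound 3, namely (chloro in place of fluoro on an aromatic carbon). It is not the same change: on compound 1 the place is meta to a fluoro group, whereas on compound 3 it is meta to a chloro group. As far as these compounds go, because the limit of > 200 nM in this assay, at which 1 of the 3 values shown sits, holds for compound 3, its true number is unknown, so any expectation for compound 4 is loose. In this assay the expected step is an at least 2.0-fold lower number from compound 3 to compound 4 (0.30 log units; that floor lies within the scatter), resting on a 7.5-fold lower number from compound 1 to compound 2 (0.88 log units; beyond the scatter). Compound 4 is therefore estimated at 100 nM, expected to fall between 20 nM and 500 nM.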

Compound 4, half-maximal inhibitory concentration: > 200 nM
Compound 4 gave a limit, no number; the forecaster's own chance of this, stated with the estimate: 35%; at least 2.0-fold (0.30 log units) between middle value and limit.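

In this assay compound 4 gives > 200 nM as a limit and not a number. Among the compounds shown here, compound 3 sits at the same limit, so no step between compound 3 and compound 4 can be read, and both remain without a true number: the limit of > 200 nM in this assay, at which 2 of the 4 values shown sit. As far as these compounds go, whether chloro in place of fluoro does on the core of compound 3 what it does on the core of compound 1 stays open.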